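The source may hold more compounds than are shown below. What is called first, only, known or untested is meant among the compounds shown, and "the series" means these compounds.

Compound 1 `COc1cc(NC(=O)c2ncccn2)c2ncccc2c1` in a functional assay on MIA PaCa-2 cells (Homo sapiens) for inhibition, read by MTT assay, with a stated time of 72 h (a lower number here means a stronger inhibitor, a higher number a weaker inhibitor), gives 1300 nM. Compound 2 `NCCOc1cc(NC(=O)c2cnccn2)c2ncccc2c1` gives > 10000 nM, which is a limit of the assay. Compound 3 `Cc1cnc(C(=O)Nc2cc(OCCN)cc3cccnc23)cn1` gives > 10000 nM, again a limit.

Compound 3 therefore stands at the limit of > 10000 nM in this assay, at which 2 of the 3 values shown sit, and its nearest neighbour, compound 2, sits there too; the step that the two limits leave unreadable from compound 2 to compound 3 cannot be sized. Compound 4 `NCCOc1cc(NC(=O)c2ncccn2)c2ncccc2c1` arises from compound 3 by pyrimidin-2-yl in place of 5-methylpyrazin-2-yl on a carbonyl carbon. For the measured compounds named here, no measured step covers this change; compound 1 carries the same pyrimidin-2-yl but a methoxy group, and its value is the only number below the limit. Compound 4 is expected to stay weak, with a step of an at least 1.2-fold lower number from compound 3 to compound 4 (0.09 log units; that floor lies within the scatter) that cannot be read against a limit, and an estimated value of 8000 nM (range 2000 nM to 30000 nM).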

Compound 4, half-maximal inhibitory concentration: > 10000 nM
Compound 4: a limit, no number (the forecaster's own chance of this, stated with the estimate: 55%); at least 1.2-fold (0.09 log units) between middle value and limit.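

For the compounds shown here, with pyrimidin-2-yl held constant, aminomethyl in place of hydrogen on a saturated chain carbon bound to an oxygen on an aromatic ring gives an at least 7.6-fold higher number from compound 1 to compound 4 (0.88 log units; beyond the scatter) in this assay, the first readable step in this set. Compound 4 gives only a limit, so its steps from compound 2 and compound 3 cannot be read. Changing the group on the carbonyl carbon brings none of these three compounds off the limit: the limit of > 10000 nM in this assay, at which 3 of the 4 values shown sit.

Going by these compounds, how far beyond the limit compounds 2, 3 and 4 lie stays open. Also open, on these data alone, is whether a hydroxyl or a dimethylamino group in place of the aminomethyl would act the same way.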